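Replacing the Oxazolyl Group with Methyl on the Aryl Ring

The source may hold more compounds than are shown below. What is called first, only, known or untested is meant among the compounds shown, and "the series" means these compounds.

Measured so far:
compound 1 `CN(C)C(=O)c1cccnc1NCCCN1CCN(c2ccccc2OCC2CC2)CC1`, 0.159 nM
compound 2 `CN(C)C(=O)c1cccnc1NCCCN1CCN(c2ccccc2-c2ncco2)CC1`, 0.316 nM

Within the data shown here, in a functional assay for antagonist activity at Alpha-1A adrenergic receptor (Oryctolagus cuniculus) (a lower number here means tighter binding, a higher number weaker binding), compound 2 gives the higher of the two numbers known, with compound 1 as its only neighbour, and the step of a 2.0-fold higher number from compound 1 to compound 2 (0.30 log units; within the scatter) is the sole measured change at this position. Compound 3 `Cc1ccccc1N1CCN(CCCNc2ncccc2C(=O)N(C)C)CC1` has not yet been measured in this assay. It differs from compound 2 by methyl in place of 1,3-oxazol-2-yl on an aromatic carbon. Among the measured compounds shown here, the one measured step that bears on this position, a 2.0-fold higher number from compound 1 to compound 2 (0.30 log units; within the scatter), lies within the scatter, so the data give no sign that what sits on this aromatic carbon moves the number much. Compound 3 is therefore expected to stay close to compound 2, with no step beyond the scatter: a 1.3-fold higher number from compound 2 to compound 3 (0.10 log units; within the scatter). The estimate for compound 3 in this assay is 0.4 nM, within a range from 0.1 nM to 1.6 nM.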

Compound 3, dissociation constant: 2 nM
For compound 3 the middle estimate is 5.0-fold (0.70 log units) below the measured one; measured number above the stated range.
By their numbers in this assay, from the lowest: compounds 1 and 2 (each within the scatter of the next); then compound 3.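

In this assay, the group on this aromatic carbon turns out to matter, which the first pair, whose step lay within the scatter, gave no sign of. Methyl in place of 1,3-oxazol-2-yl gives a 6.3-fold higher number from compound 2 to compound 3 (0.80 log units; beyond the scatter), and methyl in place of cyclopropylmethoxy gives a 13-fold higher number from compound 1 to compound 3 (1.10 log units; beyond the scatter), so both of these steps lie beyond the scatter and the methyl compound stands apart from the two whose groups carry a ring. The data at hand offer no explanation for this separation.

Three groups cannot show whether the number follows the presence of a ring in the group or simply its count of heavy atoms. From the compounds shown here alone, it remains open whether an ethyl or a methoxy group here would stay with methyl or join the other two, and how a phenyl ring or an amine would fall.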